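Nitro for chloro on the anilino ring, second position

The compounds below may be only part of what the source reports. "The series", "measured", "known", "first", "only" and "open" are said of these compounds alone.

Working notes on a small set sharing one core, tested in a functional assay on PC-3 cells (Homo sapiens) for cytotoxicity, read by MTT assay, with a stated time of 72 h; a higher number here means a weaker inhibitor, a lower number a stronger inhibitor.

Compound 1 `FC(F)(F)c1ccc(CSc2nc(Nc3cccc(Cl)c3)c3ccccc3n2)cc1` gives 13400 nM in this assay. Compound 2 `O=[N+]([O-])c1cccc(Nc2nc(SCc3ccc(C(F)(F)F)cc3)nc3ccccc23)c1` carries the change nitro in place of chloro on an aromatic carbon and gives 13500 nM in this assay; the step of a 1.0-fold higher number from compound 1 to compound 2 (0.00 log units; within the scatter) is flat. Compound 3 `FC(F)(F)c1ccc(CSc2nc(Nc3ccc(Cl)cc3)c3ccccc3n2)cc1` differs from compound 1 by 4-chlorophenyl in place of 3-chlorophenyl on a nitrogen on an aromatic ring. In this assay compound 3 gives 7110 nM. The step of a 1.9-fold lower number from compound 1 to compound 3 (0.28 log units; within the scatter) and the step of a 1.9-fold lower number from compound 2 to compound 3 (0.28 log units; within the scatter) both stay inside the scatter, so no ranking of compounds 1, 2 and 3 is drawn from these three numbers.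

Compound 4 `O=[N+]([O-])c1ccc(Nc2nc(SCc3ccc(C(F)(F)F)cc3)nc3ccccc23)cc1` is not yet measured. For the measured compounds named here, it differs from compound 3 by nitro in place of chloro on an aromatic carbon, the same kind of change as the one from compound 1 to compound 2, but not the same: in compound 1 the chloro sits meta to a large group, in compound 3 para to a large group. Going by the values given here, the only guide is the single earlier example of this change, which gave no shift.

The step from compound 3 to compound 4 is expected to be about a 1.1-fold higher number from compound 3 to compound 4 (0.02 log units; within the scatter), because the like step a 1.0-fold higher number from compound 1 to compound 2 (0.00 log units; within the scatter) did not move the number. With one precedent at a different place on the ring, the range is kept wide. Compound 4 is therefore expected to give about 7500 nM in this assay, between 3500 nM and 16000 nM.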

Compound 4, half-maximal inhibitory concentration: 7900 nM
Beside the measured number, compound 4's estimate is 1.1-fold (0.02 log units) below it, and the stated range covers the measured number.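

In this assay, nitro in place of chloro on an aromatic carbon, para to a large group, gives a 1.1-fold higher number from compound 3 to compound 4 (0.05 log units; within the scatter), and this step does not differ from the earlier one: the same change on two cores in this assay, a 1.0-fold higher number (0.00 log units; within the scatter) from compound 1 to compound 2 and a 1.1-fold higher number (0.05 log units; within the scatter) from compound 3 to compound 4, 1.1-fold (0.04 log units) apart, within the scatter of two such steps The other new steps, a 1.7-fold lower number from compound 2 to compound 4 (0.23 log units; within the scatter) and a 1.7-fold lower number from compound 1 to compound 4 (0.23 log units; within the scatter), also stay inside the scatter, so no ranking of the four compounds follows. The agreement is between two flat steps: it shows that this change left the number in place in both pairs, but it does not show that the change would stay flat on another core, or that a step of real size would carry over in the same way.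

Chloro and nitro are the only groups shown on the phenyl ring of the anilino part, so it remains open whether a methoxy, an amine or a carboxylic acid there would move the number beyond the scatter. The trifluoromethyl group is also constant across all four compounds, which leaves open what a nitrile or a methyl in its place would do, and whether the flat nitro-for-chloro step would hold alongside it.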